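The source may report more compounds than this note shows. Statements on the series, on what has been measured and on what is new or still open speak of the compounds shown alone.

Compound 1 `O=S(=O)(c1ccccc1)c1nc2ccccc2nc1Nc1ccccc1`: 590 nM
Compound 2 `COc1ccc(Nc2nc3ccccc3nc2S(=O)(=O)c2ccccc2)cc1`: 1510 nM
Compound 3 `COc1cc(Nc2nc3ccccc3nc2S(=O)(=O)c2ccc(C)cc2)cc(OC)c1`: 2940 nM

In a functional assay on PC-3 cells (Homo sapiens) for cytotoxicity, read by MTT assay, with a stated time of 72 h (a lower number here means a stronger inhibitor, a higher number a weaker inhibitor), compound 1 gives 590 nM, compound 2 gives 1510 nM and compound 3 gives 2940 nM. The change from compound 1 to compound 2 is methoxy in place of hydrogen on an aromatic carbon and it made a 2.6-fold higher number from compound 1 to compound 2 (0.41 log units; beyond the scatter). Compound 3 carries the highest of the three numbers; the difference between its core and the core of compound 1 is not broken down here. Compound 4 `COc1cc(Nc2nc3ccccc3nc2S(=O)(=O)c2ccc(C)cc2)cc(OC)c1OC` differs from compound 3 by methoxy in place of hydrogen on an aromatic carbon. Among the compounds with values here, this is the same kind of change as the one from compound 1 to compound 2, but here the entering group sits ortho to two methoxy groups, so it is not the same. For compound 4 in this assay a step of a 1.9-fold higher number from compound 3 to compound 4 (0.27 log units; within the scatter) is expected, resting on the earlier step of a 2.6-fold higher number from compound 1 to compound 2 (0.41 log units; beyond the scatter). Compound 4 is estimated at 5500 nM, between 2200 nM and 14000 nM.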

Compound 4, half-maximal inhibitory concentration: 4850 nM
Compound 4: the middle estimate sits 1.1-fold (0.05 log units) above what was measured; low and high end bracket the measured number.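

In this assay, methoxy in place of hydrogen on an aromatic carbon brought a 1.6-fold higher number from compound 3 to compound 4 (0.22 log units; within the scatter). Set beside the earlier step, the change cannot be told apart on the two cores: the same change on two cores in this assay, a 2.6-fold higher number (0.41 log units; beyond the scatter) from compound 1 to compound 2 and a 1.6-fold higher number (0.22 log units; within the scatter) from compound 3 to compound 4, 1.6-fold (0.19 log units) apart, within the scatter of two such steps. Within the data shown here, this shows that the two steps agree within what repeated measurements allow, but it does not show that the change has a fixed size across the series: there are only two pairs, and in the second the entering methoxy sits ortho to two methoxy groups.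

The compounds shown leave open how an amine or a hydroxyl would read at the place taken by that entering methoxy. They also leave open whether a longer chain, such as ethoxy, would follow the methoxy step there.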